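Vinyl for Cyano on a Weakly Cytotoxic Thiophene Amide

A few compounds are considered here, and "the series" means these few. Any claim that something is new, unique, unknown or untested is made for them only; others in the source may bear on it.

Compound 1, `C/C(=C\c1cc(C2=CCCC2)co1)C(N)=O`: in a functional assay on A549 cells (Homo sapiens) for cytotoxicity, read by CCK-8 assay, with a stated time of 24 h (a lower number here means a stronger inhibitor, a higher number a weaker inhibitor), compound 1 gives 16600 nM.
Compound 2, `C/C(=C\c1nc(-c2ccc(F)cc2)cs1)C(N)=O`: in this assay compound 2 gives 13200 nM.
Compound 3, `C/C(=C\c1cc(-c2ccc(C#N)cc2)cs1)C(N)=O`: in this assay compound 3 gives > 50000 nM, which is a limit of the assay and not a number.

Compound 3 stands at the edge of what was read: its entry is the limit of > 50000 nM in this assay, at which 1 of the 3 values shown sits, so its true value is known only to lie beyond that point. Compounds 1 and 2 both return numbers, and the two lie within the scatter of each other, so no order between them can be drawn. Within the data shown here, no pair among the three differs in a single place, so no measured step is available to lean on.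

Compound 4, `C=Cc1ccc(-c2csc(/C=C(\C)C(N)=O)c2)cc1`, departs from compound 3 by vinyl in place of cyano on an aromatic carbon, para to a large group. With no measured step of this kind in hand, and with compound 3 itself sitting at a limit, the expectation is for no change beyond the scatter, so compound 4 is expected to remain weak. Compound 4 is estimated at 45000 nM in this assay, with a range from 15000 nM to 120000 nM. The step of an at least 1.1-fold lower number from compound 3 to compound 4 (0.04 log units; that floor lies within the scatter) is expected to be small and may again end at a limit.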

Compound 4, half-maximal inhibitory concentration: > 50000 nM
Compound 4 was reported as a limit; the forecaster's own chance of this, stated with the estimate: 50%; middle value at least 1.1-fold (0.04 log units) away from the limit.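

Among these compounds, compound 3 and compound 4 both end at a limit in this assay, so no step between them can be read: the limit of > 50000 nM in this assay, at which 2 of the 4 values shown sit. The compounds shown leave open how far beyond that limit either compound lies, and whether vinyl in place of cyano on an aromatic carbon changes the value at all.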